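The source may hold more compounds than are shown below. What is called first, only, known or untested is meant among the compounds shown, and "the series" means these compounds.

Compound 1 `CCCc1nc(-c2ccccc2)c(CNCCCN2CCN(c3ccccc3C(F)(F)F)CC2)o1` was examined in an assay on HEK293 cells for inhibition of Voltage-dependent T-type calcium channel subunit alpha-1G (Homo sapiens), read by fluorescence, tested at 10 uM (on this read-out lower numbers stand for less inhibition and higher numbers for more inhibition at the one concentration tested (going by the name of the read-out)), where compound 1 gives 45%. Its companion, compound 2 `CCCc1nc(-c2ccccc2)c(CNCCN2CCN(c3ccccc3C(F)(F)F)CC2)o1`, shares the same core and the same aryl-bearing piperazine but carries a shorter chain between the two amine nitrogens; in this assay compound 2 gives 54.6%. Of the two numbers in hand, that of compound 1 is the lower, yet the gap to compound 2 lies within the scatter of repeated measurements, so the two compounds read as much alike on this measure.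

Compound 3 `CCCc1nc(-c2ccccc2)c(CNCCCN2CCN(c3ccc(C)c(C)c3)CC2)o1` keeps the longer chain of compound 1 and changes only the aryl group on the piperazine nitrogen: 3,4-dimethylphenyl in place of 2-(trifluoromethyl)phenyl on an amine nitrogen in a ring. Among the compounds with values here, no measured pair among the compounds in hand shows what this change does, so any expectation rests on the two values already seen and on the size of the change itself. Compound 3 is expected to land near compound 1, with the step of a number 5 percentage points lower from compound 1 to compound 3 (within the scatter) estimated to stay within the scatter. For compound 3 the estimate in this assay is 40%, with a range from 15% to 65%.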

Compound 3, a percentage reported as inhibition, at one concentration (the size of the read-out at that concentration, not a potency): 54.6%
Estimate against measurement, compound 3: 14.6 percentage points below, and the stated range covers the measured number.
By their numbers in this assay, from the lowest: compounds 1, 2 and 3 (each within the scatter of the next).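

Within the data shown here, compound 3 gives the first measured step at this position, on an amine nitrogen in a ring: in this assay, 3,4-dimethylphenyl in place of 2-(trifluoromethyl)phenyl gives a number 9.6 percentage points higher from compound 1 to compound 3 (within the scatter). This exchange removes all three fluorine atoms, leaves an aryl group of carbon only and goes from 10 heavy atoms to 8, yet the read-out does not separate the two compounds, so on the longer chain this measure accepts either aryl group at the one concentration tested. No other kind of measurement is available to bear on this result, and it therefore rests on the single read-out alone.

The compounds shown leave open whether a different group here, such as an unsubstituted phenyl, a methoxyphenyl or a pyridine ring, would move the number beyond the scatter of this assay. They also leave open how 3,4-dimethylphenyl behaves on the shorter chain of compound 2, and, since each number comes from one concentration, whether potency would separate these compounds.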